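Swapping fluoro for chloro on the aryl ring of compound 2

The source may report more compounds than this note shows. Statements on the series, on what has been measured and on what is new or still open speak of the compounds shown alone.

Compounds measured in a functional assay on BJAB cells (Homo sapiens) for antiproliferative activity, with a stated time of 4 days; a lower number here means that less compound is needed, a higher number that more compound is needed for the effect:
compound 1, `Cc1nn(-c2nc(-c3ccc(Cl)c(Cl)c3)c(SC(C)C)s2)c(C(=O)O)c1-c1cncnc1` — 22000 nM
compound 2, `Cc1nn(-c2nc(-c3ccc(Cl)c(Cl)c3)c(SC(C)C)s2)c(C(=O)O)c1-c1cccc(F)c1` — 900 nM
compound 3, `COc1ccccc1-c1c(C)nn(-c2nc(-c3ccc(Cl)c(Cl)c3)c(SC(C)C)s2)c1C(=O)O` — 14700 nM

All three share one core and differ only in the aromatic group attached to it. Compound 2 stands lowest of the three numbers in this assay: compound 3 gives a number a 16-fold higher number from compound 2 to compound 3 (1.21 log units; beyond the scatter), and compound 1 lies further still, as seen in a 24-fold lower number from compound 1 to compound 2 (1.39 log units; beyond the scatter) read in reverse. Both of those steps exchange the whole attached ring, not a single group on it.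

Compound 4, `Cc1nn(-c2nc(-c3ccc(Cl)c(Cl)c3)c(SC(C)C)s2)c(C(=O)O)c1-c1cccc(Cl)c1`, keeps the ring of compound 2 and changes one group on it: chloro in place of fluoro on an aromatic carbon. Among the measured compounds shown here, no measured pair here exchanges one halogen for another on this ring, so the two large steps above do not speak directly to it; they only show that this position tolerates a halogen well. With nothing pointing either way, no step beyond the scatter is expected. Compound 4 is expected to give 700 nM, with a likely range from 250 nM to 2000 nM. This would correspond to an expected step of a 1.3-fold lower number from compound 2 to compound 4 (0.11 log units; within the scatter).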

Compound 4, half-maximal effective concentration: 13600 nM
The estimate for compound 4 lay 19-fold (1.29 log units) below the measured number; measured number above the stated range.
By their numbers in this assay, from the lowest: compound 2; then compounds 4, 3 and 1 (each within the scatter of the next).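

Changing one halogen for another at this place is not a small edit: in this assay the exchange of fluoro for chloro gives a 15-fold higher number from compound 2 to compound 4 (1.18 log units; beyond the scatter) even though each group is a single heavy atom with no hydrogen-bond donors or acceptors. So the earlier good result with a halogen here belongs to 3-fluorophenyl and does not carry over to 3-chlorophenyl. The remaining steps, a 1.1-fold lower number from compound 3 to compound 4 (0.03 log units; within the scatter) and a 1.6-fold lower number from compound 1 to compound 4 (0.21 log units; within the scatter), place the 3-chlorophenyl ring alongside the 2-methoxyphenyl and pyrimidin-5-yl rings, which leaves the 3-fluorophenyl ring alone at the low end of this set. No measurement is available here that accounts for the gap between the two halogens.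

A plain phenyl ring, or a methyl, a nitrile or an amine in place of the halogen, would help show whether fluoro is the exception or chloro is the one that costs activity. Also open, going by these compounds, is whether the same halogen exchange gives a step of this size when an amide replaces the carboxylic acid on the shared core.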